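A few compounds are considered here, and "the series" means these few. Any claim that something is new, unique, unknown or untested is made for them only; others in the source may bear on it.

Among the measured compounds shown here, compound 1 `CC(=O)N1N=C(c2ccccc2)CC1c1cccc(Cl)c1Cl` is the weakest inhibitor among the three compounds measured so far. In a functional assay on HEp-2 cells (Homo sapiens) for cytotoxicity, read by sulforhodamine B assay, with a stated time of 48 h (on this read-out lower numbers stand for stronger inhibition and higher numbers for weaker inhibition), compound 1 gives 24000 nM, the highest of the three numbers recorded there. Compound 2 `COc1cc(C2CC(c3ccccc3)=NN2C(C)=O)ccc1O` gives 4990 nM in this assay, and compound 3 `COc1cc(C2CC(c3ccc(Br)cc3)=NN2C(C)=O)cc(OC)c1OC` gives 4530 nM; both of these lie beyond the usual scatter below compound 1, while the two of them sit within the scatter of each other. For the measured compounds named here, compounds 2 and 3 differ from compound 1 in more than one place, so no single step between the measured compounds can be read off.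

Compound 4 `CC(=O)N1N=C(c2ccc(Br)cc2)CC1c1cccc(Cl)c1Cl` is not yet measured in this assay. It differs from compound 1 in one place: bromo in place of hydrogen on an aromatic carbon. Going by the values given here, no measured pair shows this change by itself. Compound 3 carries the bromine-bearing ring and compound 2 does not, yet their numbers in this assay sit within the scatter of each other, and they also differ elsewhere, so the comparison gives no clean guide. The step from the change is expected to be small, if any, toward a slightly lower number, estimated as a 1.5-fold lower number from compound 1 to compound 4 (0.18 log units; within the scatter). Compound 4 is therefore expected to give about 16000 nM in this assay, within a range from 6000 nM to 40000 nM.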

Compound 4, half-maximal inhibitory concentration: 50000 nM
For compound 4 the middle estimate is 3.1-fold (0.49 log units) below the measured one; the whole stated range lies below it.
By their numbers in this assay, from the lowest: compounds 3 and 2 (each within the scatter of the next); then compound 1; then compound 4.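

The change from phenyl to 4-bromophenyl on the core of compound 1 is the first case among these compounds in which bromo in place of hydrogen can be read by itself. In this assay it brings a 2.1-fold higher number from compound 1 to compound 4 (0.32 log units; beyond the scatter), a modest step that lies beyond the scatter, so at this place on an aromatic carbon, para to a large group, the added bromine goes with weaker inhibition on this core rather than leaving the number unchanged. No measurement at hand bears on what lies behind this step.

The compounds shown leave open whether this single step carries over to the cores of compound 2 and compound 3, since neither has a partner that differs from it only by this bromine. They also leave open how the number would move if an amine, a carboxylic acid or a nitrile stood at this same place instead of bromo, and so whether the rise belongs to bromo alone or to any group placed there.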